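Replacing the amino group of compound 3

The compounds below may be only part of what the source reports. "The series", "measured", "known", "first", "only" and "open" are said of these compounds alone.

In a functional assay with Oryctolagus cuniculus as the target (a higher number here means a weaker inhibitor, a lower number a stronger inhibitor), compound 3 `COc1ccc(-c2nc(C(N)=O)sc2-c2ccc(OC)cc2)cc1` gives > 1000 nM, which is a limit and not a number. Compound 1 `COc1ccc(-c2nc(/N=C(\N)NC(C)C)sc2-c2ccc(OC)cc2)cc1` gives > 100 nM, which is also a limit. Only compound 2 `C/N=C(/NC)Nc1nc(-c2ccc(OC)cc2)c(-c2ccc(OC)cc2)s1` has a true number, at 970 nM.

Compound 4 `COc1ccc(-c2nc(C(=O)N=C(N)N)sc2-c2ccc(OC)cc2)cc1` changes compound 3 in one place: a group of 4 heavy atoms (1 carbon, 3 nitrogen; no ring) in place of one nitrogen atom, on a carbonyl carbon. The amino leaves, and the new group goes on the same carbonyl carbon.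

The measured steps say little about this change. All three are exchanges on an aromatic carbon, not on a carbonyl carbon. Two of them have no readable size: a step that the limit leaves unreadable from compound 1 to compound 2 and a step that the two limits leave unreadable from compound 1 to compound 3. The third is an at least 1.0-fold higher number from compound 2 to compound 3 (0.01 log units; that floor lies within the scatter), and its floor lies within the scatter.

Going by the values given here, the entering group holds 3 nitrogen atoms, as do the groups of compound 1 and compound 2, so the one firm anchor is compound 2 at 970 nM. Among the compounds with values here, a modest move towards a lower number is therefore expected, though no measured step fixes its size. The expected step is an at least 1.6-fold lower number from compound 3 to compound 4 (0.22 log units; that floor lies within the scatter). Compound 4 is estimated at 600 nM, with an expected range from 100 nM to 3000 nM.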

Compound 4, half-maximal inhibitory concentration: > 100 nM
Compound 4: a limit, no number (the forecaster's own chance of this, stated with the estimate: 35%); the middle value is on the limit's open side.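

In this assay compound 4 gives > 100 nM, which is a limit and not a number, so its steps to compound 1, compound 2 and compound 3 cannot be read. This limit recurs among the compounds: the limit of > 100 nM in this assay, at which 2 of the 4 values shown sit.

The compounds shown leave open whether replacing the amino group of compound 3 on the carbonyl carbon changes the read-out at all, and in which direction.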